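The source may hold more compounds than are shown below. What is called first, only, known or untested is meant among the compounds shown, and "the series" means these compounds.

Within the data shown here, in a functional assay on SK-OV-3 cells (Homo sapiens) for inhibition, read by MTT assay (on this read-out lower numbers stand for stronger inhibition and higher numbers for weaker inhibition), compound 3 `COc1ccc(/C=C2\c3cc(OC)c(OC)c(OC)c3CC[C@@H]2O)cc1C#N` gives 20 nM, the middle of the three numbers measured so far. Compound 2 `COc1ccc(/C=C2\c3cc(OC)c(OC)c(OC)c3CC[C@@H]2O)cc1F` gives 1 nM, and compound 1 `COc1ccc2c(c1)CC[C@@H](O)/C2=C/c1cc(OC)c(OC)c(OC)c1` gives 2020 nM. Compound 4 `COc1ccc(/C=C2\c3cc(OC)c(OC)c(OC)c3CC[C@@H]2O)cc1N` keeps the core of compound 3 and changes one group: amino in place of cyano on an aromatic carbon, ortho to a methoxy group (amino in place of cyano on an aromatic carbon).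

Among the measured compounds shown here, one measured step bears on this change. It is cyano in place of fluoro on that same aromatic carbon, a 20-fold higher number from compound 2 to compound 3 (1.30 log units; beyond the scatter), a large step beyond the usual scatter. It shows that the group on this carbon can move the number a long way. For the measured compounds named here, no compound with amino there has been measured yet, so the direction remains uncertain. Since the cyano group of compound 3 leaves, a moderate move towards lower numbers is expected in this assay, probably without fully reaching the number of compound 2. The expected change is a 4.0-fold lower number from compound 3 to compound 4 (0.60 log units; beyond the scatter). For compound 4 the estimate is 5 nM, with an expected range from 1 nM to 30 nM.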

Compound 4, half-maximal inhibitory concentration: 740 nM
For compound 4 the middle estimate is 150-fold (2.17 log units) below the measured one; the measured number lies above the stated range.
By their numbers in this assay, from the lowest: compound 2; then compound 3; then compound 4; then compound 1.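

In this assay, amino in place of cyano gives a 37-fold higher number from compound 3 to compound 4 (1.57 log units; beyond the scatter) and amino in place of fluoro gives a 740-fold higher number from compound 2 to compound 4 (2.87 log units; beyond the scatter) on the same aromatic carbon. Amino therefore gives the highest number of the three groups compared at this position, and the range spanned here is much wider than the fluoro and cyano pair alone revealed. Amino brings one hydrogen-bond donor where cyano has none, but no measurement here explains the rise.

The compounds shown leave open whether any group on this carbon would give a lower number than fluoro does in compound 2. They also leave open how a chloro, a hydroxyl, a methylamino or an acetamido group would compare, and the last two would show whether changing the amino group itself brings the number back down.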